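The source may hold more compounds than are shown below. What is called first, only, known or untested is meant among the compounds shown, and "the series" means these compounds.

Measured so far:
- compound 1 `CC[C@@H](C)[C@H](N)CN(C(=O)[C@@H]1C[C@H]1c1ccccc1)c1ccc(-c2ccccc2)cc1` gives 1.4 nM
- compound 2 `N[C@@H](CC1CCCCC1)CN(C(=O)[C@@H]1C[C@H]1c1ccccc1)c1ccc(-c2ccccc2)cc1` gives 1.7 nM
- compound 3 `N[C@H](CN(C(=O)[C@@H]1C[C@H]1c1ccccc1)c1ccc(-c2ccccc2)cc1)C1CCCCC1` gives 0.66 nM

All three share one core and differ only in the group on the saturated chain carbon bound to the amine nitrogen. In a functional assay for agonist activity at G protein-coupled receptor 88 (Homo sapiens), read by HTRF and cAMP accumulation (on this read-out higher numbers stand for an effect only at larger amounts of compound and lower numbers for an effect already at smaller amounts), compound 2 has the highest of the three numbers. It is close to compound 1, since a 1.2-fold higher number from compound 1 to compound 2 (0.08 log units; within the scatter), while compound 3 stands apart, because a 2.6-fold lower number from compound 2 to compound 3 (0.41 log units; beyond the scatter) and a 2.1-fold lower number from compound 1 to compound 3 (0.33 log units; beyond the scatter).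

Compound 4 `CCC(C)CNCCN(C(=O)[C@@H]1C[C@H]1c1ccccc1)c1ccc(-c2ccccc2)cc1` is not yet measured. Compared with compound 2, the difference is ((2-methylbutyl)amino)methyl in place of 1-amino-2-cyclohexylethyl on a saturated chain carbon bound to an amide-type nitrogen. The part that leaves carries the six-membered ring and the single stereocentre; the part that enters has no ring and no stereocentre, and its amine nitrogen now sits one position further along the chain.

Within the data shown here, none of the measured steps covers such a rearrangement; each of them only swaps one group on the carbon that carries the amine, and those swaps moved the number modestly at most. With the amine shifted and the ring gone, a step beyond the scatter toward higher numbers is expected, of the size an 18-fold higher number from compound 2 to compound 4 (1.25 log units; beyond the scatter), though with wide uncertainty. Compound 4 is therefore estimated at 30 nM, within a range from 3 nM to 300 nM.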

Compound 4, half-maximal effective concentration: 4.7 nM
For compound 4 the middle estimate is 6.4-fold (0.81 log units) above the measured one, within the range that was stated.
By their numbers in this assay, from the lowest: compound 3; then compounds 1 and 2 (each within the scatter of the next); then compound 4.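

In this assay, putting ((2-methylbutyl)amino)methyl in place of 1-amino-2-cyclohexylethyl on a saturated chain carbon bound to an amide-type nitrogen gives a 2.8-fold higher number from compound 2 to compound 4 (0.44 log units; beyond the scatter) and so shows that this place keeps a low number even with no ring and no defined stereocentre in the group. Measured against the two other compounds, the same kind of change gives a 3.4-fold higher number from compound 1 to compound 4 (0.53 log units; beyond the scatter) and a 7.1-fold higher number from compound 3 to compound 4 (0.85 log units; beyond the scatter) and so all three steps lie beyond the scatter and point toward higher numbers, which the earlier swaps on the amine-bearing carbon, some of them within the scatter, did not show as a shared direction. Nothing measured here accounts for these steps.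

Compound 4 differs from the others in its ring, its stereocentre and the place of its amine all at once, so the compounds shown leave open how much of the rise belongs to each of these changes. A (cyclohexylmethyl)amino group in place of the (2-methylbutyl)amino group would keep the ring with the amine where compound 4 has it, and a hydroxyl in place of the amine would test whether any nitrogen is needed at all.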